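A few compounds are considered here, and "the series" means these few. Any claim that something is new, unique, unknown or untested is made for them only; others in the source may bear on it.

The three measured compounds share a core on which a saturated chain carbon bound to a sulfur carries a varying aromatic group. Compound 1, `[O-][S+](Cc1ccc(Cl)s1)C(c1ccccc1)c1ccccc1`, has the lowest of the three numbers: in an assay on HEK293 cells for inhibition of sodium-dependent dopamine transporter (Homo sapiens), read by scintillation counting, with stated times of 5 min and 1 min (a lower number here means a stronger inhibitor, a higher number a weaker inhibitor), compound 1 gives 12800 nM. Compound 3, `[O-][S+](Cc1cc(Br)cs1)C(c1ccccc1)c1ccccc1`, gives 13700 nM, and the step of a 1.1-fold higher number from compound 1 to compound 3 (0.03 log units; within the scatter) stays within the scatter. Compound 2, `Cc1noc(C[S+]([O-])C(c2ccccc2)c2ccccc2)n1`, gives 56700 nM, and the step of a 4.4-fold higher number from compound 1 to compound 2 (0.65 log units; beyond the scatter) lies beyond the scatter.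

Compound 4, `[O-][S+](Cc1ccncc1)C(c1ccccc1)c1ccccc1`, has not yet been measured. Its difference from compound 1 is pyridin-4-yl in place of 5-chlorothiophen-2-yl on a saturated chain carbon bound to a sulfur. Among the measured compounds shown here, two measured steps bear on this change. Exchanging 5-chlorothiophen-2-yl for 4-bromothiophen-2-yl, a 1.1-fold higher number from compound 1 to compound 3 (0.03 log units; within the scatter), left the number essentially unchanged, whereas exchanging it for 3-methyl-1,2,4-oxadiazol-5-yl, a 4.4-fold higher number from compound 1 to compound 2 (0.65 log units; beyond the scatter), gave a modest rise. Pyridin-4-yl, like the oxadiazole, carries no halogen and is a ring of a different kind from the two thiophenes, so a modest rise beyond the scatter is expected in this assay for compound 4, though smaller than the one seen with compound 2, whose ring is also five-membered with three hetero atoms. The expected step is a 2.7-fold higher number from compound 1 to compound 4 (0.44 log units; beyond the scatter). Compound 4 is therefore estimated to give 35000 nM, with a range from 12000 nM to 90000 nM.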

Compound 4, half-maximal inhibitory concentration: 63500 nM
Compound 4: middle estimate off by 1.8-fold (0.26 log units), on the low side; measured number inside the range.
By their numbers in this assay, from the lowest: compounds 1 and 3 (each within the scatter of the next); then compounds 2 and 4 (each within the scatter of the next).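

In this assay, the pyridin-4-yl group shows that the rise at this place is not confined to 3-methyl-1,2,4-oxadiazol-5-yl: replacing 5-chlorothiophen-2-yl gives a 5.0-fold higher number from compound 1 to compound 4 (0.70 log units; beyond the scatter) and replacing 4-bromothiophen-2-yl gives a 4.6-fold higher number from compound 3 to compound 4 (0.67 log units; beyond the scatter), while the exchange of the two rings without a halogen gives a 1.1-fold higher number from compound 2 to compound 4 (0.05 log units; within the scatter) and so separates them by nothing that can be read. On a saturated chain carbon bound to a sulfur, the four compounds therefore form two pairs, with compounds 1 and 3 giving the lower numbers and compounds 2 and 4 the higher ones, and a six-membered aromatic ring falls in the same pair as the oxadiazole. Nothing shown here accounts for this split into two pairs.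

Going by these compounds, whether the lower numbers go with the halogen or with the thiophene ring stays open, since compounds 1 and 3 carry both and compounds 2 and 4 carry neither. An unsubstituted thiophen-2-yl or a 4-chlorophenyl group at this place would pull the two apart.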